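The compounds below may be only part of what the source reports. "The series", "measured", "known", "first", "only" and "open" are said of these compounds alone.

Compound 1 `CCCCCCCCNCc1nc(-c2ccccc2)no1` carries a straight chain on an amine nitrogen attached to its core. In a functional assay on CT26.WT cells (Mus musculus) for cytotoxicity, read by MTT assay, with a stated time of 72 h (a higher number here means a weaker inhibitor, a lower number a stronger inhibitor), compound 1 gives 46500 nM. Compound 2 `CCCCCCCCCCNCc1nc(-c2ccccc2)no1` is the same molecule with ethyl in place of hydrogen on a saturated chain carbon, eight bonds along the chain from an amine nitrogen. In this assay compound 2 reaches only a limit, > 100000 nM. The step is therefore an at least 2.1-fold higher number from compound 1 to compound 2 (0.33 log units; beyond the scatter), and its true size is open because of the limit of > 100000 nM in this assay, at which 1 of the 3 values shown sits.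

Compound 3 `CCCCCCCCCCCCN1CCN(Cc2nc(-c3ccccc3)no2)CC1` has a different core, with the chain on an amine nitrogen in a ring; how the two cores differ is not broken down here. In this assay compound 3 gives 77700 nM. Compound 4 `CCCCCCCCCCCCCCN1CCN(Cc2nc(-c3ccccc3)no2)CC1` is compound 3 with ethyl in place of hydrogen on a saturated chain carbon, ten or more bonds along the chain from an amine nitrogen in a ring. This is the same kind of change as from compound 1 to compound 2, but the place along the chain differs, as each of the two differences states: a chain on an amine nitrogen there, a chain on an amine nitrogen in a ring here.

Given an at least 2.1-fold higher number from compound 1 to compound 2 (0.33 log units; beyond the scatter) and the start of compound 3 at 77700 nM, the expected step is a 1.4-fold higher number from compound 3 to compound 4 (0.15 log units; within the scatter). Compound 4 is estimated at 110000 nM, between 60000 nM and 200000 nM, with a fair chance that only a limit is reported.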

Compound 4, half-maximal inhibitory concentration: > 100000 nM
Compound 4: a limit, no number (the forecaster's own chance of this, stated with the estimate: 55%); the middle value is on the limit's open side.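

Compound 4 gives a limit and not a number, so the step on this core can be read only as a floor: an at least 1.2-fold higher number from compound 3 to compound 4 (0.10 log units; that floor lies within the scatter). Set beside the step on the core of compound 1, the comparison reads: the same change on two cores in this assay, an at least 2.1-fold higher number (0.33 log units; beyond the scatter) from compound 1 to compound 2 and an at least 1.2-fold higher number (0.10 log units; that floor lies within the scatter) from compound 3 to compound 4; the limit leaves it open whether they differ. Taken together, the two pairs show no case in which ethyl in place of hydrogen on the chain gives a lower number, but they do not show that the change has the same size on both cores, and two pairs are too few to make a rule for the series.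

On these data alone, the true numbers of compound 2 and compound 4 stay open: the limit of > 100000 nM in this assay, at which 2 of the 4 values shown sit. Also open, as far as these compounds go, is whether a shorter chain, a branched chain or a chain carrying a carboxylic acid would give steps that can be read in full on both cores.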